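One Added Methyl on a Hydroxymethyl Side Chain

The source may hold more compounds than are shown below. What is called first, only, known or untested is meant among the compounds shown, and "the series" means these compounds.

In an ADME assay on L1210 cells (Mus musculus) for cytotoxicity, with a stated time of 48 h (on this read-out lower numbers stand for stronger inhibition and higher numbers for weaker inhibition), compound 2 `C=C1[C@H](C)CCC[C@]1(C)CC/C(C)=C/CC1=C(O)C(=O)C=C(N[C@H](CO)C(=O)O)C1=O` gives 2.6 ug/mL and compound 1 `C=C1[C@H](C)CCC[C@]1(C)CC/C(C)=C/CC1=C(O)C(=O)C=C(N[C@@H](C(=O)O)[C@H](C)O)C1=O` gives 4.6 ug/mL. For the measured compounds named here, these are the only two numbers so far, and the gap between them lies within the scatter, so compound 2 stands level with compound 1.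

Compound 3 `C=C1[C@H](C)CCC[C@]1(C)CC/C(C)=C/CC1=C(O)C(=O)C=C(N[C@@H](C(=O)O)[C@@H](C)O)C1=O` departs from compound 2 by a single change, (methyl in place of hydrogen on a saturated chain carbon bound to an oxygen on a saturated carbon and a saturated chain carbon), which turns hydroxymethyl into 1-hydroxyethyl. This places methyl in place of hydrogen on a saturated chain carbon bound to an oxygen.

Going by the values given here, only one measured step bears on this change: a 1.8-fold lower number from compound 1 to compound 2 (0.25 log units; within the scatter). It is the same exchange run in reverse. Among the compounds with values here, compound 1 also carries 1-hydroxyethyl, but its spatial arrangement at that carbon differs from that of compound 3, and no measurement yet shows what this arrangement does. With that single small step as the guide, a shift towards a slightly higher number is possible in this assay, but nothing beyond the scatter is expected.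

The expected change is a 1.5-fold higher number from compound 2 to compound 3 (0.16 log units; within the scatter). Compound 3 is estimated at 3.8 ug/mL, with an expected range from 1.6 ug/mL to 9 ug/mL.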

Compound 3, half-maximal inhibitory concentration: > 10 ug/mL
Compound 3 gave a limit, no number; the forecaster's own chance of this, stated with the estimate: 2%; at least 2.6-fold (0.42 log units) between middle value and limit.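

In this assay, methyl in place of hydrogen on this saturated chain carbon is not always a small change: the earlier pair gave only a 1.8-fold lower number from compound 1 to compound 2 (0.25 log units; within the scatter), while the new pair gives an at least 3.8-fold higher number from compound 2 to compound 3 (0.58 log units; beyond the scatter). The two compounds that carry 1-hydroxyethyl also part from each other, with an at least 2.1-fold higher number from compound 1 to compound 3 (0.33 log units; beyond the scatter), so the outcome of adding this methyl depends on how it is arranged in space and not merely on its presence, and that gap can be assigned to this one stereocentre because of a single fact: the fact that compounds 1 and 3 differ only in the configuration as drawn. On these data alone, compound 3 gave a limit and not a number, so the full size of both new steps stays unknown: the limit of > 10 ug/mL in this assay, at which 1 of the 3 values shown sits.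

The compounds shown leave open whether the drawn R arrangement at this carbon would give the same result with a longer chain in place of the methyl, or with an amine in place of the hydroxyl. They also leave open whether the gap between the two arrangements holds in any cells other than the L1210 line.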